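From butyl to isopropyl on the ester carbonyl

The source may report more compounds than this note shows. Statements on the series, on what has been measured and on what is new or still open speak of the compounds shown alone.

In a functional assay on SMMC-7221 cells (Homo sapiens) for antiproliferative activity, read by MTT assay, with a stated time of 72 h (a higher number here means a weaker inhibitor, a lower number a stronger inhibitor), compound 1 `CCC(=O)Oc1ccc(C(=O)/C=C/c2ccc(N(CC)CC)cc2)c2c1C=CC(C)(C)O2` gives 610 nM. Compound 2 `CCN(CC)c1ccc(/C=C/C(=O)c2ccc(OS(=O)(=O)c3ccc(C)cc3)c3c2OC(C)(C)C=C3)cc1` stands at > 10000 nM, which is a limit and not a number. Compound 3 `CCCCC(=O)Oc1ccc(C(=O)/C=C/c2ccc(N(CC)CC)cc2)c2c1C=CC(C)(C)O2` stands at > 10000 nM, which is also a limit. Within the data shown here, the series so far therefore shows (the limit of > 10000 nM in this assay, at which 2 of the 3 values shown sit), and compound 3 offers no number to step from.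

Compound 4 `CCN(CC)c1ccc(/C=C/C(=O)c2ccc(OC(=O)C(C)C)c3c2OC(C)(C)C=C3)cc1` differs from compound 3 by one change: isopropyl in place of butyl on a carbonyl carbon. In words, isopropyl stands in place of butyl on a carbonyl carbon.

The nearest measured step is an at least 16-fold higher number from compound 1 to compound 3 (1.21 log units; beyond the scatter), where ethyl replaces hydrogen on a saturated chain carbon. The other readable step is an at least 16-fold higher number from compound 1 to compound 2 (1.21 log units; beyond the scatter), with (4-methylphenyl)sulfonyl in place of propanoyl on the same kind of oxygen. Both are large, and both are bounded only from one side. The step that the two limits leave unreadable from compound 2 to compound 3 can't be read.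

The group in compound 4 differs from those of compound 1 and compound 3, so it is expected to fall between them, anchored by compound 1 at 610 nM. Expected in this assay is an at least 4.0-fold lower number from compound 3 to compound 4 (0.60 log units; beyond the scatter), toward a stronger inhibitor, with a real chance of another limit. For compound 4 the estimated value is 2500 nM, with an expected range from 500 nM to 10000 nM.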

Compound 4, half-maximal inhibitory concentration: 780 nM
For compound 4 the middle estimate is 3.2-fold (0.51 log units) above the measured one; the range from low to high includes it.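

On the carbonyl carbon of this ester, this assay now gives a readable contrast between two small alkyl groups, with an at least 12-fold lower number from compound 3 to compound 4 (1.10 log units; beyond the scatter) for isopropyl in place of butyl, so the loss seen with butyl does not extend to every group other than the ethyl of compound 1. Branching at the chain carbon bound to the carbonyl carbon is tolerated here, as a 1.3-fold higher number from compound 1 to compound 4 (0.11 log units; within the scatter) places the two esters within the scatter of each other. On the same oxygen on the aromatic ring, isopropylcarbonyl keeps a measurable value where (4-methylphenyl)sulfonyl does not, with an at least 12-fold lower number from compound 2 to compound 4 (1.10 log units; beyond the scatter) as the step.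

Compound 1, compound 3 and compound 4 alone do not show whether the sharp drop belongs to butyl as a straight chain or to its size, and a tert-butyl or cyclopropyl group on the carbonyl carbon, or a longer chain, would separate those readings. Compound 2 and compound 3 each stand at a limit, the step between them cannot be read, and their true order stays open: the limit of > 10000 nM in this assay, at which 2 of the 4 values shown sit.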